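The source may report more compounds than this note shows. Statements on the series, on what has been measured and on what is new or still open speak of the compounds shown alone.

Measured compounds:
compound 1, `Cc1ccc2scc(CCC(=O)N3CCC[C@H](c4ccccc4)[C@@H]3CN3CCCC3)c2c1`: 3160 nM
compound 2, `CCN(CC(=O)N1CCC[C@H](c2ccccc2)[C@@H]1CN1CCCC1)c1ccc(Cl)c(Cl)c1`: 31.6 nM

Both were tested in an assay on HEK293 cells for displacement of a labelled ligand from Urotensin-2 receptor (Homo sapiens); a higher number here means a weaker inhibitor, a lower number a stronger inhibitor. Of these two numbers compound 2 stands at the lower end, and its gap to compound 1 lies well beyond the usual scatter of repeated measurements, so compound 2 is the stronger inhibitor of the pair. Compound 3 `O=C(CN(CC1CC1)c1ccc(Cl)c(Cl)c1)N1CCC[C@H](c2ccccc2)[C@@H]1CN1CCCC1` has not yet been measured in this assay. It differs from compound 2 in one place: cyclopropyl in place of methyl on a saturated chain carbon bound to a nitrogen on an aromatic ring. For the measured compounds named here, no measured pair shows a change of this kind, so no step can be read off from the data. The exchange is a modest enlargement of a side chain away from the shared core, so the change from compound 2 is expected to be small, most likely within the scatter and in no settled direction. Compound 3 is therefore expected to give about 32 nM, with a range from 10 nM to 100 nM. That estimate means a step of a 1.0-fold higher number from compound 2 to compound 3 (0.01 log units; within the scatter), expected to stay within the scatter.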

Compound 3, inhibition constant: 50.1 nM
For compound 3 the middle estimate is 1.6-fold (0.19 log units) below the measured one; low and high end bracket the measured number.
By their numbers in this assay, from the lowest: compounds 2 and 3 (each within the scatter of the next); then compound 1.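

In this assay, for the compounds shown here, the step of a 1.6-fold higher number from compound 2 to compound 3 (0.20 log units; within the scatter) comes with cyclopropyl in place of methyl on a saturated chain carbon bound to a nitrogen on an aromatic ring, the first change at this position that can be read. The position therefore accepts 3 heavy atoms and a three-membered ring where methyl had 1 heavy atom and no ring, and the number stays within the scatter; seen one bond further out, ethyl and cyclopropylmethyl read alike here. Nothing at hand explains this result.

Still open, on these data alone, is whether the same holds for a longer chain such as n-butyl, or for a benzyl group. A chain ending in an amine or a carboxylic acid at this place could also give a very different number.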